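The compounds below may be only part of what the source reports. "The series", "measured", "known", "first", "only" and "open" are said of these compounds alone.

Compound 1 `COc1cccc(NC(=O)c2nnn(Cc3ccncc3)c2N)c1` sits at the upper limit of a toxicity assay on Vero cells (Chlorocebus sabaeus) for inhibition; a higher number here means that more compound is needed for the effect, a lower number that less compound is needed: in this assay compound 1 gives > 50100 nM, a limit and not a number. Compound 2 `COc1cccc(NC(=O)c2nnn(CC3CCN(C(C)=O)CC3)c2N)c1` likewise reaches only a limit, giving > 50100 nM in this assay. Compound 3 `COc1cccc(NC(=O)c2nnn(Cc3ccc(OC(F)(F)F)cc3)c2N)c1` also stops at a limit, giving > 50100 nM in this assay. The step that the two limits leave unreadable from compound 1 to compound 2 therefore has no readable size. Compound 4 `COc1cccc(NC(=O)c2nnn(Cc3ccc(C4CC4)cc3)c2N)c1` differs from compound 1 in one place: 4-cyclopropylphenyl in place of pyridin-4-yl on a saturated chain carbon bound to an aromatic nitrogen. Going by the values given here, the one measured step at that place, a step that the two limits leave unreadable from compound 1 to compound 2, cannot be sized, and the limit of > 50100 nM in this assay, at which 3 of the 3 values shown sit, offers no readable value at all. No step beyond the scatter is expected. Compound 4 is estimated to give 80000 nM in this assay, with a range from 30000 nM to 200000 nM. That corresponds to an expected step that the limit leaves unreadable from compound 1 to compound 4.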

Compound 4, half-maximal effective concentration: > 50100 nM
Compound 4 gave a limit, no number; the forecaster's own chance of this, stated with the estimate: 85%; the middle value does not contradict the limit.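

The steps among compound 1, compound 2, compound 3 and compound 4 cannot be read, since each compound gives only a limit in this assay: the limit of > 50100 nM in this assay, at which 4 of the 4 values shown sit.

The compounds shown leave open whether the group on the saturated chain carbon changes this read-out at all.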